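This account rests on a few compounds, and the source may have more. Where it says the series, first, only, none or still open, it means among the compounds named here.

In an assay on isolated protein for inhibition of ubiquitin carboxyl-terminal hydrolase 7 (Homo sapiens), read by fluorescence, with stated times of 30 min and 3 h (on this read-out lower numbers stand for stronger inhibition and higher numbers for weaker inhibition), compound 1 `CC(=O)c1nc([N+](=O)[O-])c(Sc2cccc(Cl)c2Cl)s1` gives 9930 nM. Compound 2 `CC(=O)c1nc([N+](=O)[O-])c(NCc2ccc(Cl)c(Cl)c2)s1` reaches only a limit of the assay, > 50000 nM, so no number is known for it. Compound 3 `CCCC(=O)OC(C)c1nc([N+](=O)[O-])c(Sc2c(Cl)cncc2Cl)s1` gives 4490 nM, the lower of the two numbers shown, and compound 1 sits beyond the scatter above it. Compound 4 `CC(NCc1ccccc1)c1nc([N+](=O)[O-])c(Sc2c(Cl)cncc2Cl)s1` differs from compound 3 in one place: benzylamino in place of (propylcarbonyl)oxy on a saturated chain carbon bound to an aromatic carbon and a saturated chain carbon. Within the data shown here, no measured pair shows this change, so its effect is open. For compound 4 in this assay a small weakening, or none beyond the scatter, is expected, a step of a 1.8-fold higher number from compound 3 to compound 4 (0.25 log units; within the scatter). Compound 4 is therefore estimated at 8000 nM, within a range from 2500 nM to 30000 nM.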

Compound 4, half-maximal inhibitory concentration: 26800 nM
For compound 4 the middle estimate is 3.4-fold (0.53 log units) below the measured one; the measured number falls inside the stated range.
By their numbers in this assay, from the lowest: compound 3; then compound 1; then compound 4. At a limit, above all of these: compound 2.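

Putting benzylamino in place of (propylcarbonyl)oxy on this saturated chain carbon gives a 6.0-fold higher number from compound 3 to compound 4 (0.78 log units; beyond the scatter) in this assay, so the group held at this carbon does influence inhibition. Compound 4 still gives a measured number, so inhibition remains measurable with benzylamino at this place. Nothing in the data shown accounts for the step. As far as these compounds go, it remains open whether the weakening goes with the benzene ring or with the amine nitrogen. A methylamino group or a plain hydroxyl on this carbon would help to separate the two.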